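A new side chain on the sulfur of compound 1

The source may hold more compounds than are shown below. What is called first, only, known or untested is meant among the compounds shown, and "the series" means these compounds.

Measured in a functional assay on MGC-803 cells (Homo sapiens) for inhibition, read by MTT assay, with a stated time of 72 h; a lower number here means a stronger inhibitor, a higher number a weaker inhibitor:
compound 1 `Cc1cc(N2CC[C@@H](C)[C@@H](N(C)c3ncnc4[nH]ccc34)C2)n2nc(SCc3nc4ccccc4[nH]3)nc2n1`: 21200 nM
compound 2 `Cc1nc2nc(SCc3ccc(Cl)cc3)nn2c(N2CC[C@@H](C)[C@@H](N(C)c3ncnc4[nH]ccc34)C2)c1C`: 90500 nM

Of these two, compound 1 has the lower number, and its gap to compound 2 lies beyond the usual scatter. Compound 3 `C=CCSc1nc2nc(C)cc(N3CC[C@@H](C)[C@@H](N(C)c4ncnc5[nH]ccc45)C3)n2n1` has not yet been measured. It differs from compound 1 in one place, with vinyl in place of 1H-benzimidazol-2-yl on a saturated chain carbon bound to a sulfur. Among the measured compounds shown here, no measured pair shows this change on its own, so the expectation is loose. In this assay a modest weakening is expected, an estimated 1.9-fold higher number from compound 1 to compound 3 (0.28 log units; within the scatter). The estimate for compound 3 is 40000 nM, within a range from 15000 nM to 100000 nM.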

Compound 3, half-maximal inhibitory concentration: 32600 nM
Beside the measured number, compound 3's estimate is 1.2-fold (0.09 log units) above it, within the range that was stated.
By their numbers in this assay, from the lowest: compounds 1 and 3 (each within the scatter of the next); then compound 2.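

In this assay, putting vinyl in place of 1H-benzimidazol-2-yl on a saturated chain carbon bound to a sulfur gives a 1.5-fold higher number from compound 1 to compound 3 (0.19 log units; within the scatter), so the two values cannot be told apart. At this position, a side chain with no ring and 2 heavy atoms in the entering group reads the same as one carrying the 9 heavy atoms of 1H-benzimidazol-2-yl. Nothing at hand explains this result. Still open, on these data alone, is whether an amine, a carboxylic acid or a longer chain at this place would read differently in this assay.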